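Ring-size and methyl variations on a guanidine acylamide core

The compounds below may be only part of what the source reports. "The series", "measured", "known", "first", "only" and "open" are said of these compounds alone.

Measured so far:
compound 1, `Cc1cc2c(cc1C(=O)N=C(N)N)S(=O)(=O)CCC2C`: 45 nM
compound 2, `Cc1cc2c(cc1C(=O)N=C(N)N)S(=O)(=O)CCCC2`: 19 nM

In an assay on cells for inhibition of sodium/hydrogen exchanger (Oryctolagus cuniculus) (on this read-out lower numbers stand for stronger inhibition and higher numbers for weaker inhibition), compound 1 gives 45 nM, the higher of the two numbers recorded. Within the data shown here, compound 2 is not a single-change partner of compound 1, so no step is counted between them; the two values show only that compound 2, with 19 nM, sits lower than compound 1 by more than the scatter.

The next compound, compound 3, `Cc1cc2c(cc1C(=O)N=C(N)N)S(=O)(=O)CCC2`, is not yet measured. It differs from compound 1 by one change: hydrogen in place of methyl on a saturated ring carbon.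

Among the measured compounds shown here, no measured pair isolates this change, and the only other compound on record differs from compound 1 in more than one place, so the direction of the step is open. The expectation is a modest move toward a lower number, possibly still within the scatter: a 1.5-fold lower number from compound 1 to compound 3 (0.18 log units; within the scatter). For compound 3 the estimated value is 30 nM, with a range from 10 nM to 90 nM.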

Compound 3, half-maximal inhibitory concentration: 95 nM
Estimate against measurement, compound 3: 3.2-fold (0.50 log units) below, and the stated range ends below it.
By their numbers in this assay, from the lowest: compound 2; then compound 1; then compound 3.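

In this assay, the change from methyl to hydrogen on this saturated ring carbon gives a 2.1-fold higher number from compound 1 to compound 3 (0.32 log units; beyond the scatter), so the position is not indifferent to this substitution. Among these compounds, this is the first single-change pair: the earlier compounds gave no direction for this position, and here the methyl-bearing compound 1 has the lower number. Nothing on record bears on why the number moves.

Going by these compounds, it remains open whether an ethyl group, a longer chain, a hydroxyl group or an amine on the same carbon would lower the number further or raise it. On these data alone, with a single pair behind it, it is also open whether the same step would appear with other substituents on the core of compound 1.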